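Methylsulfanyl in Place of Ethoxy: Expected Aorta Antagonism

The source may report more compounds than this note shows. Statements on the series, on what has been measured and on what is new or still open speak of the compounds shown alone.

Three compounds share a core in which an arylpiperazine is joined through a three-carbon linker to an aminated aromatic ring. Compound 1 `COc1ccccc1N1CCN(CCCNc2ccc(C(=O)N(C)C)cn2)CC1` gives 31.6 nM in a functional assay on aorta for antagonist activity at Alpha-1D adrenergic receptor (Rattus norvegicus); a lower number here means tighter binding, a higher number weaker binding. Compound 2 `COc1ccccc1N1CCN(CCCNc2ccccc2C(=O)c2ccccc2)CC1` gives 10 nM in this assay. Compound 3 `CCOc1ccccc1N1CCN(CCCNc2ncccc2C(=O)N(C)C)CC1` gives 7.94 nM in this assay, the lowest of the three numbers; its gap to compound 2 lies within the usual scatter, while its gap to compound 1 lies beyond it, so compound 3 and compound 2 cannot be ranked against each other on these data.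

Compound 4 `CSc1ccccc1N1CCN(CCCNc2ncccc2C(=O)N(C)C)CC1` differs from compound 3 in one place: methylsulfanyl in place of ethoxy on an aromatic carbon. For the measured compounds named here, no step between measured compounds shows what such an exchange does, so the expectation rests on the closeness of the two groups alone. Compound 4 is expected to stay close to compound 3, with a step of a 1.3-fold higher number from compound 3 to compound 4 (0.10 log units; within the scatter) that is not beyond the scatter in either direction. For compound 4 the estimate in this assay is 10 nM, with a range from 3.2 nM to 32 nM.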

Compound 4, dissociation constant: 31.6 nM
Compound 4: the middle estimate sits 3.2-fold (0.50 log units) below what was measured; the range from low to high includes it.
By their numbers in this assay, from the lowest: compounds 3 and 2 (each within the scatter of the next); then compounds 1 and 4 (each within the scatter of the next).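

The exchange of ethoxy for methylsulfanyl, on an aromatic carbon ortho to a large group, gives a 4.0-fold higher number from compound 3 to compound 4 (0.60 log units; beyond the scatter) in this assay, the only step among these compounds that isolates a change in one place. It shows that this position is sensitive to the exchange, even though both groups count one hydrogen-bond acceptor and no donors, so 2-ethoxyphenyl and 2-(methylsulfanyl)phenyl are not interchangeable here. Nothing available accounts for this step.

The compounds shown leave open whether the step follows the sulfur or the difference in heavy atoms, a question that ethylsulfanyl at this position would help to separate. They also leave open whether the same exchange would give a similar step on the core of compound 2.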